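The source may report more compounds than this note shows. Statements on the series, on what has been measured and on what is new or still open speak of the compounds shown alone.

Values so far in a functional assay on A549 cells (Homo sapiens) for cytotoxicity, read by MTT assay, with a stated time of 72 h (on this read-out higher numbers stand for weaker inhibition and lower numbers for stronger inhibition), are these:
- compound 1 (`COc1ncc(-c2ccc3nc(NC(=O)NCCN4CCCCC4)nn3c2)cc1NS(=O)(=O)c1ccc(F)cc1`) gives 610 nM
- compound 2 (`COc1ncc(-c2ccc3nc(NC(=O)NCC(=O)N4CCOCC4)nn3c2)cc1NS(=O)(=O)c1ccc(F)cc1`) gives 2570 nM
- compound 3 (`CCN(CC)CCNC(=O)Nc1nc2ccc(-c3cnc(OC)c(NS(=O)(=O)c4ccc(F)cc4F)c3)cn2n1`) gives 980 nM

Compound 3 lies within the scatter of compound 1, and both stand beyond the scatter from compound 2, whose number is the highest of the three. The change to compound 4 (`CCN(CC)CCNC(=O)Nc1nc2ccc(-c3cnc(OC)c(NS(=O)(=O)c4ccc(Cl)cc4)c3)cn2n1`) is 4-chlorophenyl in place of 2,4-difluorophenyl on a sulfonyl sulfur and nothing else in the molecule differs. Going by the values given here, the one measured step (a 4.2-fold higher number from compound 1 to compound 2 (0.62 log units; beyond the scatter)) lies elsewhere, on a saturated chain carbon bound to an amide-type nitrogen, so it says nothing about the group on the sulfonyl sulfur. Compound 1 and compound 3 differ in more than one place, so their closeness settles nothing either. Among the compounds with values here, with no measured step bearing on this change, the expectation rests on compound 3 at 980 nM alone, and no shift beyond the scatter is expected. The expected step is small (a 1.1-fold lower number from compound 3 to compound 4 (0.04 log units; within the scatter)) and its direction is open. In this assay compound 4 is estimated at 900 nM with a range from 400 nM to 2000 nM as its likely span.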

Compound 4, half-maximal inhibitory concentration: 680 nM
Compound 4: the middle estimate sits 1.3-fold (0.12 log units) above what was measured, within the range that was stated.
By their numbers in this assay, from the lowest: compounds 1, 4 and 3 (each within the scatter of the next); then compound 2.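

In this assay, the first step measured at the sulfonyl sulfur is a 1.4-fold lower number from compound 3 to compound 4 (0.16 log units; within the scatter), so 4-chlorophenyl in place of 2,4-difluorophenyl cannot be told apart from no change here. At this position, this exchange of aryl groups therefore leaves the number within the scatter, unlike the step on the chain, a 4.2-fold higher number from compound 1 to compound 2 (0.62 log units; beyond the scatter), which lies beyond it. Nothing available here accounts for this result.

As far as these compounds go, whether a smaller or different group on the sulfonyl sulfur, such as methyl, a pyridyl ring or 4-methoxyphenyl, would also stay within the scatter remains open. Going by these compounds alone, also open is whether the same exchange would give a similar step with the chain carried by compound 1 or compound 2 in place of the one shared by compound 3 and compound 4.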